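The source may report more compounds than this note shows. Statements on the series, on what has been measured and on what is new or still open speak of the compounds shown alone.

Measured so far:
- compound 1 `CC(C)=CCC/C(C)=C/CC/C(C)=C/CC[C@@H]1[C@@]2(C)CC/C(=N\OCc3cn(-c4cccc(O)c4)nn3)C(C)(C)[C@@H]2CC[C@@]1(C)O`: 21200 nM
- compound 2 `CC(C)=CCC/C(C)=C/CC/C(C)=C/CC[C@@H]1[C@@]2(C)CC/C(=N\OCc3cn(-c4ccc(F)c(Cl)c4)nn3)C(C)(C)[C@@H]2CC[C@@]1(C)O`: 58900 nM
- compound 3 `CC(C)=CCC/C(C)=C/CC/C(C)=C/CC[C@@H]1[C@@]2(C)C/C(=C\c3ccc(OCc4cn(-c5cccc(O)c5)nn4)cc3)C(=O)C(C)(C)[C@@H]2CC[C@@]1(C)O`: 26900 nM

In a functional assay on HepG2 cells (Homo sapiens) for cytotoxicity, read by MTT assay, with a stated time of 48 h (a lower number here means a stronger inhibitor, a higher number a weaker inhibitor), compound 1 gives 21200 nM and compound 2 gives 58900 nM. The change between them is 3-chloro-4-fluorophenyl in place of 3-hydroxyphenyl on an aromatic nitrogen and the step is a 2.8-fold higher number from compound 1 to compound 2 (0.44 log units; beyond the scatter). Compound 3 carries a different core; the difference between the two cores is not broken down here. In this assay compound 3 gives 26900 nM, within the scatter of compound 1.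

Compound 4 `CC(C)=CCC/C(C)=C/CC/C(C)=C/CC[C@@H]1[C@@]2(C)C/C(=C\c3ccc(OCc4cn(-c5ccc(F)c(Cl)c5)nn4)cc3)C(=O)C(C)(C)[C@@H]2CC[C@@]1(C)O` is not yet measured. It differs from compound 3 by 3-chloro-4-fluorophenyl in place of 3-hydroxyphenyl on an aromatic nitrogen, the same change as from compound 1 to compound 2. The step is expected to be similar, a 2.6-fold higher number from compound 3 to compound 4 (0.42 log units; beyond the scatter), because the step of a 2.8-fold higher number from compound 1 to compound 2 (0.44 log units; beyond the scatter) is the only prior read on this change. Compound 4 is therefore estimated at 70000 nM in this assay, between 30000 nM and 160000 nM.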

Compound 4, half-maximal inhibitory concentration: 40200 nM
For compound 4 the middle estimate is 1.7-fold (0.24 log units) above the measured one; the measured number falls inside the stated range.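

In this assay, 3-chloro-4-fluorophenyl in place of 3-hydroxyphenyl on the aromatic nitrogen gives a 1.5-fold higher number from compound 3 to compound 4 (0.17 log units; within the scatter), so on this core the change cannot be told apart from repeat scatter. The two reads of the change do not differ beyond what two such steps can scatter: the same change on two cores in this assay, a 2.8-fold higher number (0.44 log units; beyond the scatter) from compound 1 to compound 2 and a 1.5-fold higher number (0.17 log units; within the scatter) from compound 3 to compound 4, 1.9-fold (0.27 log units) apart, within the scatter of two such steps. This is compatible with the change carrying over between these two cores, but two pairs, one of them within the scatter, do not establish that it does, nor say anything about any other core.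

The compounds shown leave open how either core responds when an amine or a carboxylic acid sits on the phenyl group. From the compounds shown here alone, a longer chain between the aromatic nitrogen and the phenyl group also remains open.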